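This account rests on a few compounds, and the source may have more. Where it says the series, first, only, none or still open, it means among the compounds named here.

Among the compounds with values here, compound 2 `COc1ccc2c(OCc3nnc4sc(-c5ccc(F)cc5)nn34)ccnc2c1` carries a 4-fluorophenyl group on its fused core and is the one compound here with a number: in a functional assay on EBC-1 cells (Homo sapiens) for antiproliferative activity, with a stated time of 72 h (a lower number here means a stronger inhibitor, a higher number a weaker inhibitor), compound 2 gives 187 nM. Compound 1 `COc1ccc2c(OCc3nnc4sc(-c5cc6cc(F)ccc6[nH]5)nn34)ccnc2c1`, which shares the same core, is recorded in this assay as "not determined" (no result reported), so compound 2 stands alone on the numbers shown, with nothing above or below it to compare against. Compound 3 `COc1ccc2c(OCc3nnc4sc(-c5ccn(CC6CC6)c5)nn34)ccnc2c1` is made from compound 2 by a single exchange: 1-(cyclopropylmethyl)-1H-pyrrol-3-yl in place of 4-fluorophenyl on an aromatic carbon. Within the data shown here, no two measured compounds differ in just one place, so there is no measured step to lean on for this exchange. The step is expected to be modest and could run either way, most likely toward a somewhat weaker inhibitor, as a 1.6-fold higher number from compound 2 to compound 3 (0.21 log units; within the scatter). Compound 3 is therefore estimated to give 300 nM in this assay, within a range of 60 nM to 1500 nM.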

Compound 3, half-maximal inhibitory concentration: 351 nM
Compound 3: the middle estimate sits 1.2-fold (0.07 log units) below what was measured; the range from low to high includes it.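

In this assay, within the data shown here, the exchange of 4-fluorophenyl for 1-(cyclopropylmethyl)-1H-pyrrol-3-yl gives a 1.9-fold higher number from compound 2 to compound 3 (0.27 log units; within the scatter), the first measured step at this position. Compound 2 and compound 3 therefore cannot be told apart in this assay, even though the entering group has 9 heavy atoms against 7 and replaces the six-membered aromatic ring with a five-membered aromatic ring and a three-membered ring. No supporting data bear on why the number stays within the scatter.

The step swaps the ring and the cyclopropylmethyl part together, so a pyrrole carrying only a methyl group on its nitrogen would be needed to show what each part contributes. Going by these compounds, it also remains open whether this position would accept a very different group, such as an amine or a carboxylic acid.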